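Adding a hydroxy group to compound 3

This account rests on a few compounds, and the source may have more. Where it says the series, first, only, none or still open, it means among the compounds named here.

In a functional assay on MCF7 cells (Homo sapiens) for antiproliferative activity, read by sulforhodamine B assay, with a stated time of 48 h (on this read-out higher numbers stand for weaker inhibition and lower numbers for stronger inhibition), compound 3 (`COc1ccc(C(=O)/C=C/c2ccccc2-c2ccc(F)nc2)cc1`) reads 13000 nM and so lies within the scatter of compound 2 (`COc1ccc(C(=O)/C=C/c2ccccc2-c2ccc(F)cc2)cc1`) at 8800 nM but clearly apart from compound 1 (`COc1cc(/C=C/C(=O)c2ccccc2-c2ccc(F)cc2)ccc1O`) at 4000 nM on the lower side. Compound 4 (`COc1ccc(C(=O)/C=C/c2ccccc2-c2ccc(F)nc2)cc1O`) differs from compound 3 by a single change (hydroxy in place of hydrogen on an aromatic carbon): hydroxy in place of hydrogen on an aromatic carbon, ortho to a methoxy group. Within the data shown here, the one measured single-place step, a 1.5-fold higher number from compound 2 to compound 3 (0.17 log units; within the scatter) and so within the scatter, concerns a different group and says little about this change. Among the measured compounds shown here, the only hint comes from compound 1 at 4000 nM which also carries a hydroxy group, though it differs from compound 2 in more than one place. For the measured compounds named here, no measured pair tests the hydroxy group directly. A modest move towards a lower number is therefore expected, with the estimated step being a 2.0-fold lower number from compound 3 to compound 4 (0.30 log units; within the scatter) and uncertain. Compound 4 is estimated at 6500 nM with an expected range of 2200 nM to 17000 nM for repeated measurements.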

Compound 4, half-maximal inhibitory concentration: 2000 nM
The estimate for compound 4 lay 3.3-fold (0.51 log units) above the measured number, outside the stated range (below it).
By their numbers in this assay, from the lowest: compounds 4 and 1 (each within the scatter of the next); then compounds 2 and 3 (each within the scatter of the next).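

In this assay, among these compounds, the hydroxy group in place of hydrogen on an aromatic carbon, ortho to a methoxy group, gives a 6.5-fold lower number from compound 3 to compound 4 (0.81 log units; beyond the scatter) and is the only single-place step here that lies beyond the scatter. The earlier step of a 1.5-fold higher number from compound 2 to compound 3 (0.17 log units; within the scatter) stayed within the scatter, so this carbon of the carbon-only six-membered aromatic ring is the one place among those shown where a single change clearly moves the number. Nothing available explains why the hydroxy group has this effect.

The compounds shown leave open whether an amine or a carboxylic acid on this same carbon would read like the hydroxy group. They also leave open whether the step would carry over to compound 2 with its 4-fluorophenyl group.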